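From Cyclohexyl to Phenoxy in a Growth Inhibition Study

This account rests on a few compounds, and the source may have more. Where it says the series, first, only, none or still open, it means among the compounds named here.

compound 1 `O=C(CCl)NC(=O)Nc1ccc(C2CCCCC2)cc1` gives 2300 nM
compound 2 `O=C(CCl)NC(=O)Nc1cccc(OC2CCCCCC2)c1` gives 6900 nM

In a functional assay on HT-29 cells (Homo sapiens) for inhibition, read by sulforhodamine B assay, with a stated time of 48 h (on this read-out lower numbers stand for stronger inhibition of growth and higher numbers for weaker inhibition of growth), compound 1 gives 2300 nM and so holds the lower of the two numbers. Compound 2 gives 6900 nM on the same read-out, and the gap between them lies beyond the usual scatter. Going by the values given here, the two measured compounds differ in more than one place, so no single-change step is available to show what one substitution does here.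

Compound 3 `O=C(CCl)NC(=O)Nc1ccc(Oc2ccccc2)cc1` has not yet been measured. It departs from compound 1 by a single change, phenoxy in place of cyclohexyl on an aromatic carbon. Among the compounds with values here, with no measured step to set a size or a direction, the expectation in this assay is for no shift beyond the scatter, and either direction stays open. The estimated change is small: a 1.3-fold higher number from compound 1 to compound 3 (0.12 log units; within the scatter). For compound 3 the expected value is 3000 nM, with an estimated range running from 1000 nM to 9000 nM as the measurement is awaited.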

Compound 3, concentration for 50% growth inhibition: 3600 nM
Compound 3: the middle estimate sits 1.2-fold (0.08 log units) below what was measured; measured number inside the range.
By their numbers in this assay, from the lowest: compounds 1, 3 and 2 (each within the scatter of the next, the first and the last beyond it).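

In this assay, going by these compounds alone, placing phenoxy in place of cyclohexyl on an aromatic carbon, para to a group of 8 heavy atoms, gives a 1.6-fold higher number from compound 1 to compound 3 (0.19 log units; within the scatter), the first single-change step that can be read in this set. At this position, therefore, a six-membered non-aromatic ring of carbon only and a phenoxy group, which brings a hydrogen-bond acceptor where cyclohexyl has none, are not told apart by this read-out, even though the two groups differ in ring type and in heavy atoms. Nothing measured here bears on why the two groups give numbers within the scatter of each other.

The compounds shown leave open whether the same holds for quite different groups at this place, such as an amine, a carboxylic acid or a longer alkyl chain. They also leave open how phenoxy itself would read on a different carbon of the ring, and whether a single step in another part of the core of compound 1 would move the number beyond the scatter.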